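Carbamate rearrangement on the biaryl dimethylaniline series

The compounds below may be only part of what the source reports. "The series", "measured", "known", "first", "only" and "open" are said of these compounds alone.

Measured so far in an assay on COS-7 cells for inhibition of patatin-like phospholipase domain-containing protein 2 (Mus musculus); on this read-out higher numbers stand for weaker inhibition and lower numbers for stronger inhibition:
compound 1 `CN(C)C(=O)Nc1cccc(-c2ccc(N(C)C)cc2)c1`: < 5000 nM
compound 2 `CC(C)OC(=O)Nc1cccc(-c2ccc(N(C)C)cc2)c1`: 82000 nM

The value of compound 1 is a limit of this assay, not a number (the limit of < 5000 nM in this assay, at which 1 of the 2 values shown sits). Compound 2 therefore holds the only numeric result shown, and within this assay there is nothing to rank it against beyond that limit. Among the measured compounds shown here, the single measured step, an at least 16-fold higher number from compound 1 to compound 2 (1.21 log units; beyond the scatter), exchanges the group on the carbonyl carbon.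

Compound 3 `CCOC(=O)N(C)c1cccc(-c2ccc(N(C)C)cc2)c1` carries the same atoms as compound 2 arranged differently: (ethoxycarbonyl)(methyl)amino in place of (isopropoxycarbonyl)amino on an aromatic carbon. The measured step does not touch the nitrogen on the ring and so does not bear on this change; it shows only that the carbonyl side of this substituent can move the number a long way. For the measured compounds named here, with no step resembling the present one, no shift beyond the scatter is assumed. Compound 3 is expected at about 60000 nM in this assay, within 15000 nM to 200000 nM, which means an expected 1.4-fold lower number from compound 2 to compound 3 (0.14 log units; within the scatter).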

Compound 3, half-maximal inhibitory concentration: > 200000 nM
Compound 3: only a limit was reported; the forecaster's own chance of this, stated with the estimate: 20%; at least 3.3-fold (0.52 log units) between middle value and limit.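

In this assay the value of compound 3 is a limit, not a number: the limit of > 200000 nM in this assay, at which 1 of the 3 values shown sits.

The limit still lets the step be read: an at least 2.4-fold higher number from compound 2 to compound 3 (0.38 log units; beyond the scatter) shows that rearranging the same atoms on this aromatic carbon, from (isopropoxycarbonyl)amino to (ethoxycarbonyl)(methyl)amino, is enough to weaken inhibition, a change that also takes the count of hydrogen-bond donors in the group from 1 to 0. Against the best compound, an at least 40-fold higher number from compound 1 to compound 3 (1.60 log units; beyond the scatter) widens the gap seen on the carbonyl side alone.

The change alters the nitrogen and the alkoxy chain together, so the compounds shown leave open which of the two carries the step. From the compounds shown here alone, the (ethoxycarbonyl)amino and (isopropoxycarbonyl)(methyl)amino groups would separate them, and how much weaker compound 3 truly is stays open.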